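From 4-methoxyphenyl to 2-methylphenyl on the sulfonyl sulfur

The source may hold more compounds than are shown below. What is called first, only, known or untested is meant among the compounds shown, and "the series" means these compounds.

Compound 1: `COc1ccccc1S(=O)(=O)Nc1ccc(-c2nc3ccccc3o2)cc1` — > 100000 nM
Compound 2: `COc1ccc(S(=O)(=O)Nc2ccc(-c3nc4ccccc4o3)cc2)cc1` — > 100000 nM

In an assay on cells for inhibition of HSP60/HSP10 (Homo sapiens), with a stated time of 60 min (a higher number here means a weaker inhibitor, a lower number a stronger inhibitor), compound 1 gives > 100000 nM, a limit of the assay rather than a number. Compound 2 gives > 100000 nM, likewise a limit. Compound 2 therefore stands at the limit, where both values sit (the limit of > 100000 nM in this assay, at which 2 of the 2 values shown sit). Among the measured compounds shown here, the only measured step, a step that the two limits leave unreadable from compound 1 to compound 2, is unreadable for that reason. Compound 3 `Cc1ccccc1S(=O)(=O)Nc1ccc(-c2nc3ccccc3o2)cc1` differs from compound 2 by 2-methylphenyl in place of 4-methoxyphenyl on a sulfonyl sulfur. For the measured compounds named here, no measured step bears on this change, so no direction or size beyond the scatter can be expected from the numbers. Compound 3 is estimated at 100000 nM, within 30000 nM to 300000 nM. This estimate means an expected step of a number no higher from compound 2 to compound 3 (the limit leaves the size open).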

Compound 3, half-maximal inhibitory concentration: 85000 nM
Beside the measured number, compound 3's estimate is 1.2-fold (0.07 log units) above it, and the stated range covers the measured number.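

In this assay, compound 3 is the first compound shown to give a number instead of a limit, so steps at this sulfonyl sulfur can now be read, though only as floors. The change to 2-methylphenyl gives an at least 1.1-fold lower number from compound 2 to compound 3 (0.07 log units; that floor lies within the scatter), and methyl in place of methoxy on an aromatic carbon gives an at least 1.1-fold lower number from compound 1 to compound 3 (0.07 log units; that floor lies within the scatter). Most values shown still stand at a limit: the limit of > 100000 nM in this assay, at which 2 of the 3 values shown sit.

Going by these compounds, how far either step exceeds its floor stays open. So does what an amine or a carboxylic acid on the sulfonyl sulfur's phenyl ring would do to the number.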